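Fluoro for methoxy on the phenylsulfanyl arm

The source may report more compounds than this note shows. Statements on the series, on what has been measured and on what is new or still open speak of the compounds shown alone.

Compound 1 `COc1cc(CNc2nc3cc(N)cc(N)c3nc2-c2ccccc2)cc(OC)c1OC`: in a functional assay on K562 cells (Homo sapiens) for inhibition, read by sulforhodamine B assay, with a stated time of 48 h (on this read-out higher numbers stand for weaker inhibition of growth and lower numbers for stronger inhibition of growth), compound 1 gives < 50200 nM, which is a limit of the assay.
Compound 2 `COc1ccc(CNc2nc3cc(N)cc(N)c3nc2-c2ccccc2)cc1`: in this assay compound 2 gives 97700 nM.
Compound 3 `COc1ccc(Sc2nc3cc(N)cc(N)c3nc2-c2ccccc2)cc1`: in this assay compound 3 gives < 100000 nM, which is a limit of the assay.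

Compound 3 stands at the limit of < 100000 nM in this assay, at which 1 of the 3 values shown sits, so only a bound and no number is known for it. Of the other two values, compound 1 also rests at a bound, (the limit of < 50200 nM in this assay, at which 1 of the 3 values shown sits), and only compound 2 carries a measured number. Among the compounds with values here, no two of the three differ in a single place, so no step among them can be read.

Compound 4 `Nc1cc(N)c2nc(-c3ccccc3)c(Sc3ccc(F)cc3)nc2c1` differs from compound 3 by fluoro in place of methoxy on an aromatic carbon. Within the data shown here, nothing among the measured compounds tells how this exchange acts in this assay. The author expects for compound 4 a step from compound 3 that stays within the scatter, a step that the limit leaves unreadable from compound 3 to compound 4. The estimate for compound 4 in this assay is 60000 nM, with a range from 20000 nM to 100000 nM.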

Compound 4, concentration for total growth inhibition: 38900 nM
Compound 4: middle estimate off by 1.5-fold (0.19 log units), on the high side, within the range that was stated.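

No new step can be read: the exchange from compound 3 to compound 4 has no readable size, because compound 3 rests at a limit: the limit of < 100000 nM in this assay, at which 1 of the 4 values shown sits.

The compounds shown leave open how far fluoro in place of methoxy on this arm shifts growth inhibition in this assay.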